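This account rests on a few compounds, and the source may have more. Where it says the series, first, only, none or still open, it means among the compounds named here.

In a functional assay on HeLa cells (Homo sapiens) for inhibition, read by sulforhodamine B assay, with a stated time of 74 h (a lower number here means a stronger inhibitor, a higher number a weaker inhibitor), compound 1 `Cc1ccc(S(=O)(=O)N2C(=O)COC23C=CC(=O)C=C3)cc1` gives 180 nM. Compound 2 `O=C1C=CC2(C=C1)OCC(=O)N2S(=O)(=O)c1ccc(Cl)cc1` is reported as > 10000 nM, which is a limit of the assay and not a number. Among the compounds with values here, the only measured step is large: an at least 55-fold higher number from compound 1 to compound 2 (1.74 log units; beyond the scatter), with chloro in place of methyl on an aromatic carbon. Compound 3 `O=C1C=CC2(C=C1)OCC(=O)N2S(=O)(=O)c1cccs1` carries thiophen-2-yl in place of 4-chlorophenyl on a sulfonyl sulfur, so the chloro of compound 2 leaves with its ring. Within the data shown here, that single step, an at least 55-fold higher number from compound 1 to compound 2 (1.74 log units; beyond the scatter), is the only guide, and it shows that one small change on this aryl group can shift this assay by a wide margin. A return toward stronger inhibition is therefore expected, though its size is uncertain. The expected change is an at least 10-fold lower number from compound 2 to compound 3 (1.00 log units; beyond the scatter). For compound 3 the estimated value is 1000 nM, with an expected range from 150 nM to 10000 nM.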

Compound 3, half-maximal inhibitory concentration: 3420 nM
Estimate against measurement, compound 3: 3.4-fold (0.53 log units) below, and the stated range covers the measured number.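

In this assay, the sulfonyl sulfur tolerates more than a swap of one substituent: exchanging the whole aromatic ring restores a measurable value, with an at least 2.9-fold lower number from compound 2 to compound 3 (0.46 log units; beyond the scatter). Compound 2 is reported only as a limit, so this step gives a minimum size and not an exact one: the limit of > 10000 nM in this assay, at which 1 of the 3 values shown sits. Thiophen-2-yl still does not match 4-methylphenyl, with a 19-fold higher number from compound 1 to compound 3 (1.28 log units; beyond the scatter), so compound 1 remains the strongest inhibitor of the three, and a measurable value at this position does not by itself mean high potency.

From the compounds shown here alone, it remains open whether the methyl group or the six-membered ring matters more for the strength of compound 1, a question that plain phenyl could help to separate. Also open, going by these compounds, is how a methoxy group or an amine on the ring would shift the number.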